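A few compounds are considered here, and "the series" means these few. Any claim that something is new, unique, unknown or untested is made for them only; others in the source may bear on it.

Series built on the shared core of compound 1 `O=C(O)CCc1ccc(OCc2nnc(C(=O)Nc3ccccc3)s2)cc1`, which in a functional assay on CHO cells for agonist activity at Free fatty acid receptor 1 (Homo sapiens), read by calcium flux (a higher number here means that more compound is needed for the effect, a lower number that less compound is needed), gives 1060 nM. Compound 2 `Cc1ccccc1NC(=O)c1nnc(COc2ccc(CCC(=O)O)cc2)s1` adds a methyl on an aromatic carbon, and in this assay compound 2 gives 1520 nM; the step of a 1.4-fold higher number from compound 1 to compound 2 (0.16 log units; within the scatter) stays within the scatter. Compound 3 `COc1cccc(NC(=O)c2nnc(COc3ccc(CCC(=O)O)cc3)s2)c1` carries a methoxy instead, and in this assay compound 3 gives 4680 nM, the highest of the three numbers, standing a 4.4-fold higher number from compound 1 to compound 3 (0.64 log units; beyond the scatter) and a 3.1-fold higher number from compound 2 to compound 3 (0.49 log units; beyond the scatter) away from the other two. Compound 4 `O=C(O)CCc1ccc(OCc2nnc(C(=O)Nc3cccc(Cl)c3)s2)cc1` is the next step from compound 3: chloro in place of methoxy on an aromatic carbon, on an aromatic carbon of a six-membered aromatic ring of carbon only, meta to a large group. Within the data shown here, no measured step exchanges these two groups directly. Among the measured compounds shown here, the steps that bear on it are a 4.4-fold higher number from compound 1 to compound 3 (0.64 log units; beyond the scatter), which sets the size of the methoxy effect at this place, and a 1.4-fold higher number from compound 1 to compound 2 (0.16 log units; within the scatter), which shows a small group elsewhere left the number within the scatter. Compound 4 is therefore expected to return part of the way, to an estimated 1600 nM, in the range 600 nM to 4500 nM. The expected step is a 2.9-fold lower number from compound 3 to compound 4 (0.47 log units; beyond the scatter), likely beyond the scatter.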

Compound 4, half-maximal effective concentration: 10600 nM
Estimate against measurement, compound 4: 6.6-fold (0.82 log units) below; the measured number lies above the stated range.
By their numbers in this assay, from the lowest: compounds 1 and 2 (each within the scatter of the next); then compound 3; then compound 4.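

In this assay chloro at this place, meta to a large group, does not bring the number back: a 2.3-fold higher number from compound 3 to compound 4 (0.36 log units; beyond the scatter) is a further rise, and a 10-fold higher number from compound 1 to compound 4 (1.00 log units; beyond the scatter) exceeds a 4.4-fold higher number from compound 1 to compound 3 (0.64 log units; beyond the scatter) for methoxy on the same carbon. Both groups thus raise the number over hydrogen here, removing the methoxy oxygen does not lower it, and a 7.0-fold higher number from compound 2 to compound 4 (0.84 log units; beyond the scatter) sets the 3-chlorophenyl compound clearly apart from the 2-methylphenyl one as well. Nothing measured here explains this order.

Open, from the compounds shown here alone, is whether any group at this place keeps the number near that of compound 1, for instance an amine or a hydroxyl. Also open, going by these compounds, is whether chloro or methoxy on other carbons of this ring behaves the same way, given that the methyl of compound 2 stays within the scatter of hydrogen.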